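Swapping Indole for Pyrazole on the Shared Core

This account rests on a few compounds, and the source may have more. Where it says the series, first, only, none or still open, it means among the compounds named here.

Compound 1 `Cc1nn(C)c(-n2cccc2)c1/C=N/OCc1ccc(C(=O)OC(C)(C)C)cc1`: 2.48 ug/mL
Compound 2 `Cc1nn(C)c(-n2ccc3ccccc32)c1/C=N/OCc1ccc(C(=O)OC(C)(C)C)cc1`: 1.57 ug/mL

In a functional assay on HCT-15 cells (Homo sapiens) for cytotoxicity (a lower number here means a stronger inhibitor, a higher number a weaker inhibitor), compound 2 gives 1.57 ug/mL. That value lies within the usual scatter of compound 1 at 2.48 ug/mL, so the two cannot be ranked against each other.

The next structure is compound 3 `Cc1nn(C)c(-n2cccn2)c1/C=N/OCc1ccc(C(=O)OC(C)(C)C)cc1`, which keeps the shared core and the rest of the molecule. Its change is 1H-pyrazol-1-yl in place of 1H-indol-1-yl on an aromatic carbon.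

Going by the values given here, only one measured step bears on this, and it involves the same aromatic carbon: a 1.6-fold lower number from compound 1 to compound 2 (0.20 log units; within the scatter). That exchange of 1H-pyrrol-1-yl for 1H-indol-1-yl stayed within the scatter. Among the compounds with values here, no compound carrying 1H-pyrazol-1-yl has been measured yet, so this small step is a thin guide. It gives no reason to expect a large shift in this assay, although a slightly higher number seems likelier than a lower one. The expected move is a 1.5-fold higher number from compound 2 to compound 3 (0.18 log units; within the scatter), which would stay within the scatter. For compound 3 the expected value is 2.4 ug/mL, with an estimated range of 1.1 ug/mL to 5.5 ug/mL.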

Compound 3, half-maximal inhibitory concentration: 3.63 ug/mL
Beside the measured number, compound 3's estimate is 1.5-fold (0.18 log units) below it; measured number inside the range.
By their numbers in this assay, from the lowest: compounds 2, 1 and 3 (each within the scatter of the next, the first and the last beyond it).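

In this assay, this aromatic carbon now gives its first step beyond the scatter, since the change shows a 2.3-fold higher number from compound 2 to compound 3 (0.36 log units; beyond the scatter) and so the group placed here can move the number, if only modestly. The other new comparison, with a single-ring group on each side, shows a 1.5-fold higher number from compound 1 to compound 3 (0.17 log units; within the scatter) and stays within the scatter, so 1H-pyrazol-1-yl and 1H-pyrrol-1-yl cannot be ranked against each other and the second ring nitrogen of 1H-pyrazol-1-yl brings no readable change of its own. No measured evidence is available to explain why the 1H-indol-1-yl and 1H-pyrazol-1-yl compounds separate.

Only these three aromatic ring groups have been compared here, and compound 1 remains within the scatter of both compound 2 and compound 3, so the data give only a shallow picture of this position. As far as these compounds go, whether a group of another kind on this carbon, such as an open-chain amine, a chlorine atom or a phenyl ring, would lower the number further or raise it well beyond this narrow span remains open.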